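The source may report more compounds than this note shows. Statements on the series, on what has been measured and on what is new or still open speak of the compounds shown alone.

Measured so far in an ADME assay on Vero cells (Chlorocebus sabaeus) for cytotoxicity, with a stated time of 72 h, tested at 10 ug/mL; a higher number here means a stronger effect of the compound at the concentration tested, a lower number a weaker effect:
- compound 1 `O=c1[nH]nc2n(c1=O)CCN2c1ccccc1`: 7%
- compound 2 `COc1ccccc1N1CCn2c1n[nH]c(=O)c2=O`: 26%

In this assay compound 1 gives 7%, and compound 2 gives 26%. For the measured compounds named here, compound 1 therefore stands at the lower end of the two numbers known so far; its nearest neighbour is compound 2, reached by a single change, and that step, a number 19 percentage points higher from compound 1 to compound 2 (beyond the scatter), is the only one available for comparison.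

Compound 3 `O=c1[nH]nc2n(c1=O)CCN2c1cccc(Cl)c1` has not yet been measured. It differs from compound 1 in one place: chloro in place of hydrogen on an aromatic carbon. The step from compound 1 to compound 2 involves methoxy in place of hydrogen on an aromatic carbon, so it concerns a different entering group from the chloro of compound 3, and it bears on the new compound only loosely. It does show that adding a single group to this ring can move the number by a modest amount. An increase of similar or smaller size is expected for compound 3 in this assay, possibly one that does not clear the usual scatter, giving an expected step of a number 7 percentage points higher from compound 1 to compound 3 (within the scatter). The estimate for compound 3 is 14%, within a range from 0% to 32%.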

Compound 3, a percentage reported as inhibition, at one concentration (the size of the read-out at that concentration, not a potency): 11%
Beside the measured number, compound 3's estimate is 3 percentage points above it, within the range that was stated.
By their numbers in this assay, from the lowest: compounds 1 and 3 (each within the scatter of the next); then compound 2.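

In this assay, chloro in place of hydrogen on an aromatic carbon, meta to a large group, gives a number 4 percentage points higher from compound 1 to compound 3 (within the scatter) and so leaves compound 3 indistinguishable from compound 1. Compound 2 had suggested that a single added group on this ring could shift the number, with methoxy giving a number 19 percentage points higher from compound 1 to compound 2 (beyond the scatter); the chloro result shows that such an addition does not always clear the scatter. The two steps differ both in the entering group and in where it sits on the ring, and no measurement shown here explains the contrast between them.

The compounds shown leave open whether a different group at this same place, such as an amine or a carboxylic acid, would carry the number beyond the scatter. They also leave open whether the contrast between the two steps follows the group or its place, which could be tested by putting methoxy meta to the same large group, so that it sits where the chloro of compound 3 sits.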